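This account rests on a few compounds, and the source may have more. Where it says the series, first, only, none or still open, it means among the compounds named here.

In a functional assay on MCF7 cells (Homo sapiens) for antiproliferative activity, read by MTT assay, with a stated time of 48 h (on this read-out lower numbers stand for stronger inhibition and higher numbers for weaker inhibition), three compounds have been measured so far:

Compound 1, `N#CC1=C(N)Oc2c(c3nc4ccccc4nc3c3ccccc23)C12C(=O)N(Cc1cnnn1-c1ccccc1Br)c1ccccc12`, gives > 50000 nM, a limit of the assay.
Compound 2, `N#CC1=C(N)Oc2c(c3nc4ccccc4nc3c3ccccc23)C12C(=O)N(Cc1cnnn1-c1ccc(F)c(Cl)c1)c1ccccc12`, gives > 50000 nM, also a limit.
Compound 3, `Cc1cccc(-n2nncc2CN2C(=O)C3(C(C#N)=C(N)Oc4c(N)cc5nc6ccccc6nc5c43)c3ccccc32)c1`, gives > 50000 nM, again a limit.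

Compound 3 therefore stands at the limit rather than at a number, and the two other compounds stand there with it, as the limit of > 50000 nM in this assay, at which 3 of the 3 values shown sit, records. Among the compounds with values here, the only comparison between measured compounds that differ in one place, a step that the two limits leave unreadable from compound 1 to compound 2, is 3-chloro-4-fluorophenyl in place of 2-bromophenyl on an aromatic nitrogen; with both ends at the limit, its size cannot be read. Compound 4, `CCc1cccc(C)c1-n1nncc1CN1C(=O)C2(C(C#N)=C(N)Oc3c(N)cc4nc5ccccc5nc4c32)c2ccccc21`, differs from compound 3 by 2-ethyl-6-methylphenyl in place of 3-methylphenyl on an aromatic nitrogen. Within the data shown here, no measured step bears directly on this change, and no measured step has a readable size at all. Three values at the limit give no ground to expect a number for compound 4 either, so the expected step of a number no higher from compound 3 to compound 4 (the limit leaves the size open) is set at none beyond the scatter. Compound 4 is estimated at 50000 nM, in the range 20000 nM to 120000 nM, with the assay most likely again reporting only a limit.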

Compound 4, half-maximal inhibitory concentration: > 50000 nM
Compound 4 was reported as a limit (the forecaster's own chance of this, stated with the estimate: 80%); the middle value lies on the limit itself.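

Within the data shown here, with compound 3 and compound 4 both reported only as limits, the step between them cannot be read, and no new step follows: the limit of > 50000 nM in this assay, at which 4 of the 4 values shown sit.

The compounds shown leave open whether any of them would give a measurable value in this assay and how far changing the group on the aromatic nitrogen would move it.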